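The source may report more compounds than this note shows. Statements on the series, on what has been measured and on what is new or still open speak of the compounds shown alone.

Among the measured compounds shown here, in a functional assay on HeLa cells (Homo sapiens) for antiproliferative activity, with a stated time of 5 days (a lower number here means a stronger inhibitor, a higher number a weaker inhibitor), compound 1 `O=C1C=CC2(C=C1)OCC(=O)N2c1nc(-c2ccc3c(c2)OCCO3)nn1-c1ccccc1` gives 70 nM, while compound 2 `O=C1C=CC2(C=C1)OCC(=O)N2c1nc(-c2ccc3ccccc3c2Br)nn1-c1ccccc1` gives 290 nM, the higher and therefore weaker of the two numbers so far. Compound 3 `O=C1C=CC2(C=C1)OCC(=O)N2c1nc(-c2ccc(F)c3ccccc23)nn1-c1ccccc1` keeps the shared core, but 4-fluoronaphthalen-1-yl takes the place of 1-bromonaphthalen-2-yl on an aromatic carbon of the five-membered aromatic ring with 3 nitrogen (4-fluoronaphthalen-1-yl in place of 1-bromonaphthalen-2-yl on an aromatic carbon). For the measured compounds named here, only one measured step bears on this change: a 4.1-fold higher number from compound 1 to compound 2 (0.62 log units; beyond the scatter), a modest move made by replacing a group at this same place. Going by the values given here, one step is thin evidence, and no measured compound yet carries a fluorine. Compound 2 sits at the top of the small range at 290 nM, so a smaller step towards a lower number is expected, namely a 2.2-fold lower number from compound 2 to compound 3 (0.35 log units; beyond the scatter). For compound 3, the estimated value is 130 nM, with an expected range of 35 nM to 480 nM.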

Compound 3, half-maximal inhibitory concentration: 200 nM
Beside the measured number, compound 3's estimate is 1.5-fold (0.19 log units) below it; the measured number falls inside the stated range.
By their numbers in this assay, from the lowest: compound 1; then compounds 3 and 2 (each within the scatter of the next).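

In this assay, putting 4-fluoronaphthalen-1-yl in place of 1-bromonaphthalen-2-yl gives a 1.5-fold lower number from compound 2 to compound 3 (0.16 log units; within the scatter), so this position tolerates this exchange of one halogenated naphthalene group for another without a change that can be told from the scatter. Against 2,3-dihydro-1,4-benzodioxin-6-yl, the new group gives a 2.9-fold higher number from compound 1 to compound 3 (0.46 log units; beyond the scatter), so both naphthalene groups shown, not only the bromine-bearing one, stand on the weaker side of compound 1. No measurement here explains why these groups differ in this way.

Going by these compounds, the two naphthalene groups differ both in their halogen and in their point of attachment, so the share of each stays open, and 4-bromonaphthalen-1-yl or plain naphthalen-1-yl would separate them. Also open, on these data alone, is how a phenyl group carrying an amine or a carboxylic acid would fare at this place.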